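This account rests on a few compounds, and the source may have more. Where it says the series, first, only, none or still open, it means among the compounds named here.

Measured compounds and their values:

compound 1 `O=C(/C=C/c1ccc2c(c1)B(O)OC2)c1cccnc1` — 20500 nM
compound 2 `O=C(/C=C/c1ccc2c(c1)B(O)OC2)c1ccc(OCc2ccccc2)cc1` — 12100 nM
compound 3 `O=C(/C=C/c1ccc2c(c1)B(O)OC2)c1ccc(Cl)c(Cl)c1` — 3200 nM

All three share one core and differ only in the aryl group attached to the carbonyl carbon. In a functional assay on HCT-116 cells (Homo sapiens) for cytotoxicity, read by MTT assay, with a stated time of 48 h (a lower number here means a stronger inhibitor, a higher number a weaker inhibitor), compound 1 gives 20500 nM, the highest of the three numbers. Compound 2, with 12100 nM, sits within the usual scatter of compound 1, so the two cannot be told apart. Compound 3, with 3200 nM, lies clearly beyond that scatter and is the strongest inhibitor of the three.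

Compound 4 `Nc1cccc(C(=O)/C=C/c2ccc3c(c2)B(O)OC3)c1` has not yet been measured. It differs from compound 1 in one place: 3-aminophenyl in place of pyridin-3-yl on a carbonyl carbon. The six-membered ring on the carbonyl carbon thus keeps its size but loses its ring nitrogen and gains an amino group carrying a hydrogen-bond donor.

Among the measured compounds shown here, no step between two measured compounds matches this change, so the direction must be judged from the three numbers alone. Both carbon-only rings measured so far, in compound 2 and compound 3, give lower numbers than compound 1. A modest step downward is therefore expected, though it may well stay within the scatter. Compound 4 is estimated at 12000 nM in this assay, with a range from 4000 nM to 36000 nM, which corresponds to an expected step of a 1.7-fold lower number from compound 1 to compound 4 (0.23 log units; within the scatter).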

Compound 4, half-maximal inhibitory concentration: 4500 nM
Beside the measured number, compound 4's estimate is 2.7-fold (0.43 log units) above it; the measured number falls inside the stated range.
By their numbers in this assay, from the lowest: compounds 3 and 4 (each within the scatter of the next); then compounds 2 and 1 (each within the scatter of the next).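

Among the compounds shown, this is the first pair that differs in only one place. In this assay, among the compounds shown here, putting 3-aminophenyl in place of pyridin-3-yl on the carbonyl carbon gives a 4.6-fold lower number from compound 1 to compound 4 (0.66 log units; beyond the scatter) and so shows that the number responds to this group even when the six-membered aromatic ring keeps its size, something the earlier compounds could only hint at, since no two of them formed such a pair. The change removes the ring nitrogen and adds the amino group at the same time, and nothing here separates those two parts or says why the number moves.

From the compounds shown here alone, it remains open whether losing the ring nitrogen is enough by itself, a question that a plain phenyl group on the carbonyl carbon would answer. Going by these compounds, it is equally open whether the amino group itself matters or whether another small group would serve as well, which a hydroxyl or a methyl group in its place would help to settle.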